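The source may hold more compounds than are shown below. What is called first, only, known or untested is meant among the compounds shown, and "the series" means these compounds.

In a physicochemical assay for inhibition, with a stated time of 7 days (a higher number here means a weaker inhibitor, a lower number a stronger inhibitor), compound 1 (`COc1cccc(NC(=O)Nc2cccc(Cl)c2)c1`) gives 5800 nM and compound 2 (`Cc1cc(C)cc(NC(=O)Nc2cccc(Cl)c2)c1`) gives 906000 nM as the higher of the two numbers, well beyond the scatter. Compound 3 (`Cc1cc(C)cc(NC(=O)Nc2ccccc2)c1`) differs from compound 2 by hydrogen in place of chloro on an aromatic carbon with hydrogen in place of chloro on an aromatic carbon. Within the data shown here, no measured pair shows this change alone, so the size of the step in this assay remains poorly defined. A small rise is expected, estimated as a 1.3-fold higher number from compound 2 to compound 3 (0.12 log units; within the scatter) and possibly within the scatter. Compound 3 is estimated at 1200000 nM in a range from 200000 nM to 6000000 nM until it is measured.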

Compound 3, half-maximal inhibitory concentration: "not active" (no number reported)
Compound 3 has no reported number here; no gap can be computed for the estimate.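

In this assay, among these compounds, compound 3 has no reported number, so no step from compound 2 to compound 3 can be read. The compounds shown leave open how much the chloro group contributes to inhibition. No evidence bears on this result.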